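Chain length and growth inhibition of hydroxamic acid anilides

The source may report more compounds than this note shows. Statements on the series, on what has been measured and on what is new or still open speak of the compounds shown alone.

Measured so far:
compound 1, `C#CCN(C)Cc1cccc(NC(=O)CCCCCCCCC(=O)NO)c1` — 2940 nM
compound 2, `C#CCN(C)Cc1ccc(NC(=O)CCCC(=O)NO)cc1` — > 10000 nM

Two anilides that share a propargyl-methylamino-benzyl core were tested in a functional assay on DU-145 cells (Homo sapiens) for inhibition, read by MTT assay, with a stated time of 48 h; a higher number here means a weaker inhibitor of growth, a lower number a stronger inhibitor of growth. Compound 1 gives 2940 nM in this assay. For compound 2 the result in this assay is only a limit, > 10000 nM, so no number is known for it. Compound 2 therefore stands at the limit of > 10000 nM in this assay, at which 1 of the 2 values shown sits, the upper edge of what this assay can report, and its true value may lie anywhere beyond it.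

Compound 3, `C#CCN(C)Cc1ccc(NC(=O)CCCCCCCC(=O)NO)cc1`, has not yet been measured in this assay. It differs from compound 2 in one place: 4-(hydroxycarbamoyl)butyl in place of hydroxycarbamoyl on a saturated chain carbon, three bonds along the chain from a carbonyl carbon. In plain terms, the hydroxamic acid end of the chain is carried further from the anilide carbonyl by a longer saturated linker.

Among the measured compounds shown here, no measured step exists here between two numbers, so the size of this change cannot be read off directly. Still, compound 1, which also carries a long chain to its hydroxamic acid, gives 2940 nM, well inside the range of this assay. Compound 3 is therefore expected to be a clearly stronger inhibitor of growth than compound 2, with the step from compound 2 to compound 3 estimated as an at least 3.3-fold lower number from compound 2 to compound 3 (0.52 log units; beyond the scatter), beyond the scatter. The estimate for compound 3 in this assay is 3000 nM, with a range from 1000 nM to 9000 nM.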

Compound 3, concentration for 50% growth inhibition: 3400 nM
Beside the measured number, compound 3's estimate is 1.1-fold (0.05 log units) below it, within the range that was stated.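

In this assay compound 2 has > 10000 nM as a limit and not as a number. With 4-(hydroxycarbamoyl)butyl in place of hydroxycarbamoyl on a saturated chain carbon, three bonds along the chain from a carbonyl carbon, the series gains its first readable step, an at least 2.9-fold lower number from compound 2 to compound 3 (0.46 log units; beyond the scatter), which shows that this change at this position brings growth inhibition within the range the assay can report. This step is a minimum and not an exact size, since the true value of the shorter compound could lie further out than the reported edge: the limit of > 10000 nM in this assay, at which 1 of the 3 values shown sits.

The compounds shown give only two chain lengths on this core with this ring arrangement, so they cannot tell whether growth inhibition keeps strengthening with a still longer chain or peaks at some length in between. As far as these compounds go, it also remains open whether the gain depends on the hydroxamic acid at the chain end, a question that a carboxylic acid or an amine in its place, on the chain of compound 3, would help to answer.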